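The source may report more compounds than this note shows. Statements on the series, on what has been measured and on what is new or still open speak of the compounds shown alone.

In a functional assay on MGC-803 cells (Homo sapiens) for antiproliferative activity, read by MTT assay (on this read-out lower numbers stand for stronger inhibition and higher numbers for weaker inhibition), compound 2, `COc1cc2ncnc(NCc3cccc(NC(=O)Nc4ccccc4)c3)c2cc1OC`, gives 10000 nM. Among the measured compounds shown here, compound 1, `CC(C)(C)c1ccc(NC(=O)Nc2cccc(CNc3ncnc4ccccc34)c2)cc1`, is the only other compound measured here; in this assay compound 1 gives 7470 nM, and the gap between the two numbers lies within the usual scatter of such measurements. Compound 3, `COc1ccc(NC(=O)Nc2cccc(CNc3ncnc4cc(OC)c(OC)cc34)c2)cc1`, differs from compound 2 in one place: methoxy in place of hydrogen on an aromatic carbon. For the measured compounds named here, no measured pair of compounds shows this change, so nothing is known about its effect. For compound 3 the expected step is a 1.3-fold lower number from compound 2 to compound 3 (0.10 log units; within the scatter), meaning no change beyond the scatter in either direction. Compound 3 is therefore estimated at 8000 nM, in a range from 3000 nM to 20000 nM.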

Compound 3, half-maximal inhibitory concentration: 12300 nM
Estimate against measurement, compound 3: 1.5-fold (0.19 log units) below; the measured number falls inside the stated range.
By their numbers in this assay, from the lowest: compounds 1, 2 and 3 (each within the scatter of the next).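

Placing methoxy on the phenyl ring in place of hydrogen, para to a large group, gives a 1.2-fold higher number from compound 2 to compound 3 (0.09 log units; within the scatter) in this assay. Among the compounds shown here, this is the first direct reading of the change, and it shows that methoxy at this position leaves the number unchanged within the scatter. No measurement available here bears on this result. From the compounds shown here alone, whether another group at the same position, such as an amine or a carboxylic acid, would shift the number beyond the scatter remains open. So does whether methoxy would act the same way at another place on the ring.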